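Cyclohexyl to naphthyl on the macrocycle side chain

A few compounds are considered here, and "the series" means these few. Any claim that something is new, unique, unknown or untested is made for them only; others in the source may bear on it.

Compound 1 `CCC[C@@H]1NC(=O)[C@@H](C(C)C)NC(=O)[C@@H](CCCCN)NCCOc2ccccc2/C=C/CNC1=O`: in an assay on isolated protein for displacement of a labelled ligand from Motilin receptor (Homo sapiens) (a lower number here means a stronger inhibitor, a higher number a weaker inhibitor), compound 1 gives > 10000 nM, a limit of the assay.
Compound 2 `CCC[C@@H]1NC(=O)[C@@H](C(C)C)NC(=O)[C@@H](Cc2ccc(O)cc2)NCCc2ccccc2CCCNC1=O`: in this assay compound 2 gives > 10000 nM, also a limit.
Compound 3 `CCC[C@@H]1NC(=O)[C@@H](C(C)C)NC(=O)[C@@H](CC2CCCCC2)NCCOc2ccccc2CCCNC1=O`: in this assay compound 3 gives 3250 nM.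

Among the compounds with values here, compound 3 holds the only measured number in the set; the other two entries sit at the limit of > 10000 nM in this assay, at which 2 of the 3 values shown sit. Within the data shown here, no pair among the three differs in a single place, so no measured step can be read, and what compound 1 and compound 2 show is only that each stays at the limit while compound 3 does not.

Compound 4 `CCC[C@@H]1NC(=O)[C@@H](C(C)C)NC(=O)[C@@H](Cc2cccc3ccccc23)NCCOc2ccccc2CCCNC1=O` is the same as compound 3 apart from naphthalen-1-yl in place of cyclohexyl on a saturated chain carbon bound to a saturated ring carbon. Among the measured compounds shown here, with no measured step to lean on, the expectation is for a modest gain beyond the scatter, since the entering group and the leaving group are of comparable bulk and only the ring type changes. Compound 4 is therefore estimated at 1500 nM, within 300 nM to 8000 nM. That estimate means a step of a 2.2-fold lower number from compound 3 to compound 4 (0.34 log units; beyond the scatter) in this assay.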

Compound 4, inhibition constant: 8.3 nM
Compound 4: the middle estimate sits 180-fold (2.26 log units) above what was measured; measured number below the stated range.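

Within the data shown here, on the side chain, on a saturated chain carbon bound to a saturated ring carbon, naphthalen-1-yl in place of cyclohexyl gives a 390-fold lower number from compound 3 to compound 4 (2.59 log units; beyond the scatter) in this assay, the first step that can be read. It shows that the group at this place can shift the number strongly while the rest of the macrocycle stays the same. Neither group carries hydrogen-bond donors, hydrogen-bond acceptors or a net charge, so a step of this size does not need any of these in the entering group.

The compounds shown leave open whether phenyl, naphthalen-2-yl or a naphthalen-1-yl group bearing an amine would keep this gain at the same place. No measurement shown gives a cause for the size of the step.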